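Swapping a methoxymethyl for methylsulfanyl on the shared core

This account rests on a few compounds, and the source may have more. Where it says the series, first, only, none or still open, it means among the compounds named here.

Measured compounds:
- compound 1, `COCc1nc2nc(C)cc(Nc3ccc(S(F)(F)(F)(F)F)cc3)n2n1`: 2.8
- compound 2, `COCc1nc2nc(C)cc(Nc3ccc(C(F)(F)F)cc3)n2n1`: 2.5
- compound 3, `Cc1cc(Nc2ccc(Cl)cc2)n2nc(C(C)C)nc2n1`: 3.2

In a physicochemical assay for lipophilicity, at pH 7.4 (a lower number here means a more polar compound, a higher number a more lipophilic compound), compound 2 gives 2.5, the lowest of the three numbers. Compound 1 sits close to it, the step of a number 0.30 log units lower from compound 1 to compound 2 (within the scatter) lying within the scatter. Compound 3 lies further off: its value of 3.2 is beyond the scatter above compound 2, though compound 3 differs from compound 2 in two places, so no single step can be read from that pair.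

Compound 4, `CSc1nc2nc(C)cc(Nc3ccc(C(F)(F)F)cc3)n2n1`, has not yet been measured. It differs from compound 2 in one place: methylsulfanyl in place of methoxymethyl on an aromatic carbon. For the measured compounds named here, none of the measured steps touches this position of the shared core, so there is no directly comparable step; the one measured step, a number 0.30 log units lower from compound 1 to compound 2 (within the scatter), concerns a different ring. An estimate for compound 4 must therefore rest on the general run of the three values and on the nature of the exchange. Compound 4 is expected to come out somewhat higher than compound 2, a step of about a number 0.50 log units higher from compound 2 to compound 4 (beyond the scatter) in this assay. The estimate for compound 4 is 3, with an expected range from 2.6 to 3.4.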

Compound 4, distribution coefficient: 3.2
The estimate for compound 4 lay 0.20 log units below the measured number, within the range that was stated.
By their numbers in this assay, from the lowest: compounds 2 and 1 (each within the scatter of the next); then compounds 3 and 4 (each within the scatter of the next).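

Moving from methoxymethyl to methylsulfanyl on this aromatic carbon of the shared core gives a number 0.70 log units higher from compound 2 to compound 4 (beyond the scatter) in this assay, so this position can change the reading by more than the usual scatter. For the compounds shown here, the only earlier one-place change, a number 0.30 log units lower from compound 1 to compound 2 (within the scatter), was made elsewhere on the molecule and did not show this, and here the number moves although the counts of hydrogen-bond donors and acceptors are the same for the two groups and neither carries a net charge. No measurement shown here explains why the number moves.

From the compounds shown here alone, it remains open whether an amine, a methoxy group or a longer chain such as ethylsulfanyl at this position would read nearer compound 2 or compound 4. It is also unknown whether the same exchange would produce a similar step on the core of compound 1.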